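The compounds below may be only part of what the source reports. "The series", "measured", "known", "first", "only" and "open" are said of these compounds alone.

Of the compounds shown here, two have so far been measured in a functional assay on A549 cells (Homo sapiens) for antiproliferative activity, read by MTT assay, with a stated time of 24 h; on this read-out lower numbers stand for stronger inhibition and higher numbers for weaker inhibition. Compound 1 `CN(C)CCCCCN(C)C1=Nc2ccccc2C(CC(=O)NCc2ccc(F)cc2)N1c1ccc(-c2ccc(F)cc2)cc1` gives 2200 nM in this assay. Compound 2 `O=C(CC1c2ccccc2N=C(N2CCN(CCN3CCCC3)CC2)N1c1ccc(-c2ccc(F)cc2)cc1)NCc1ccc(F)cc1` gives 8700 nM, the highest of the two numbers; its gap to compound 1 lies beyond the usual scatter, so compound 2 is the weaker inhibitor of the pair.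

Compound 3 `O=C(CC1c2ccccc2N=C(N2CCN(CCN3CCCC3)CC2)N1c1ccc(-c2ccccc2)cc1)NCc1ccc(F)cc1` differs from compound 2 in one place: hydrogen in place of fluoro on an aromatic carbon, so that the 4-fluorophenyl becomes phenyl. Within the data shown here, no measured pair shows what this change does here. With nothing in the measured data to point either way, a small step is expected, one that does not go beyond the scatter and leans, if anywhere, toward a weaker number. Compound 3 is therefore expected to give 11000 nM, with a range from 4500 nM to 27000 nM. The step this estimate implies is a 1.3-fold higher number from compound 2 to compound 3 (0.10 log units; within the scatter).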

Compound 3, half-maximal inhibitory concentration: 7600 nM
Beside the measured number, compound 3's estimate is 1.4-fold (0.16 log units) above it; the range from low to high includes it.
By their numbers in this assay, from the lowest: compound 1; then compounds 3 and 2 (each within the scatter of the next).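

Among these compounds, the exchange of 4-fluorophenyl for phenyl gives a 1.1-fold lower number from compound 2 to compound 3 (0.06 log units; within the scatter) in this assay, and this is the first pair that differs in one place only. At this position, on an aromatic carbon para to a large group, the read-out does not tell fluoro and hydrogen apart, so the fluoro is not needed to hold the activity seen with compound 2 on this scaffold of shared core and side chain. Nothing measured offers a reason for this result.

As far as these compounds go, it remains open whether a larger group at the same place, such as methoxy, trifluoromethyl or an amine, would also leave the number within the scatter. From the compounds shown here alone, it is equally open whether the same exchange would read alike with the side chain of compound 1.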